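The source may report more compounds than this note shows. Statements on the series, on what has been measured and on what is new or still open speak of the compounds shown alone.

Compound 1 `Cc1ccc(OCC(=O)N(CCO)Cc2cccs2)cc1`: 900 nM
Compound 2 `CCN(Cc1cccnc1)C(=O)COc1ccc(C)cc1`: 15400 nM
Compound 3 `CCN(Cc1cccs1)C(=O)COc1ccccc1C`: 192 nM

These three compounds were examined in an assay on HEK293 cells for agonist activity at transient receptor potential cation channel subfamily M member 8 (Homo sapiens), read by fluorescence and calcium flux, with a stated time of 15 min; on this read-out lower numbers stand for an effect already at smaller amounts and higher numbers for an effect only at larger amounts of compound. Compound 1 stands at the second highest of the three numbers. Its nearest neighbour is compound 3, whose number lies lower by a margin beyond the usual scatter; furthest from it is compound 2, whose number lies higher, again beyond the scatter. The three compounds differ from one another in more than one place, so none of these gaps can be tied to a single change.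

The next compound, compound 4 `Cc1ccc(OCC(=O)N(O)Cc2cccs2)cc1`, has not yet been measured in this assay. It differs from compound 1 in one place only: hydroxy in place of 2-hydroxyethyl on an amide-type nitrogen. The amide-type nitrogen in compound 1 carries the 2-hydroxyethyl chain; in compound 4 that chain is replaced by the shorter hydroxy group, the counts of hydrogen-bond donors and acceptors staying the same.

For the measured compounds named here, no measured pair in this set shows this change, so the direction must be judged without a precedent. The author expects the step from compound 1 to compound 4 to be a modest loss, a 2.0-fold higher number from compound 1 to compound 4 (0.30 log units; within the scatter), only slightly beyond the scatter. On that basis compound 4 is estimated at 1800 nM, within a range from 500 nM to 6500 nM.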

Compound 4, half-maximal effective concentration: 8000 nM
The estimate for compound 4 lay 4.4-fold (0.65 log units) below the measured number, outside the stated range (above it).
By their numbers in this assay, from the lowest: compound 3; then compound 1; then compounds 4 and 2 (each within the scatter of the next).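

Replacing 2-hydroxyethyl with hydroxy on the amide-type nitrogen gives an 8.9-fold higher number from compound 1 to compound 4 (0.95 log units; beyond the scatter) in this assay, the first gap in this set that can be tied to a single change. It shows that this nitrogen's substituent is not interchangeable on the core of compound 1: the entering and leaving groups have the same counts of hydrogen-bond donors and acceptors, yet those matching counts did not keep the number in place, so what differs in this pair is the loss of the 2 carbon atoms and the drop from 3 heavy atoms to 1. No measurement offered here accounts for the size of this step.

The compounds shown leave open whether the step follows the length of the chain or the oxygen standing directly on the nitrogen, a question that a methoxy group, a 3-hydroxypropyl chain or a 2-methoxyethyl chain at the same place could help to separate. They also leave open how a 2-aminoethyl chain or a carboxylic acid on a chain of this kind would read on the same core.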